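The compounds below may be only part of what the source reports. "The series", "measured", "known", "first", "only" and "open" are said of these compounds alone.

Working notes on the series

All compounds share one core, carried in compound 1 `Cc1ccc([C@H](C)NC(=O)Cn2nnc3ccccc3c2=O)cc1`. In an ADME assay on microsomes from liver (Homo sapiens) for metabolic stability (on this read-out lower numbers stand for slow clearance and higher numbers for fast clearance), compound 1 gives < 9.9 mL/min/kg, and this value is a limit of the assay rather than a number. Compound 2 `C[C@H](NC(=O)Cn1nnc2ccccc2c1=O)c1ccc(F)cc1` differs from compound 1 by fluoro in place of methyl on an aromatic carbon. In this assay compound 2 gives 31 mL/min/kg. Compound 3 `Cc1ccc([C@H](C)NC(=O)Cn2nnc3ccccc3c2=O)c(C)c1` differs from compound 1 by methyl in place of hydrogen on an aromatic carbon. In this assay compound 3 gives 33 mL/min/kg. The measured steps read an at least 3.1-fold higher number from compound 1 to compound 2 (0.49 log units; beyond the scatter) and an at least 3.3-fold higher number from compound 1 to compound 3 (0.52 log units; beyond the scatter), both of which start from a limit, (the limit of < 9.9 mL/min/kg in this assay, at which 1 of the 3 values shown sits), so only their lower bounds are known; between the two numbers the step is a 1.1-fold higher number from compound 2 to compound 3 (0.03 log units; within the scatter), and compound 2 and compound 3 cannot be ordered.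

Compound 4 `Cc1ccc([C@H](C)NC(=O)Cn2nnc3ccccc3c2=O)c(F)c1` is not yet measured. It differs from compound 3 by fluoro in place of methyl on an aromatic carbon. The same kind of change is made from compound 1 to compound 2, where the place is para to a large group, whereas in compound 4 the place is ortho to a large group and meta to a methyl group. Among the measured compounds shown here, the one measured instance of this change, an at least 3.1-fold higher number from compound 1 to compound 2 (0.49 log units; beyond the scatter), gives only a lower bound on its size. For compound 4 the step is expected to be a 1.2-fold lower number from compound 3 to compound 4 (0.07 log units; within the scatter), resting on compound 3 with 33 mL/min/kg and on compound 2 with 31 mL/min/kg, which already carry a methyl or fluoro at a comparable place without separating. Compound 4 is therefore estimated at 28 mL/min/kg, with a plausible span from 13 mL/min/kg to 55 mL/min/kg.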

Compound 4, clearance in the Homo sapiens assay: 28 mL/min/kg
Compound 4: middle estimate and measured number agree at the digits printed; the measured number falls inside the stated range.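

In the Homo sapiens assay compound 1 gives < 9.9 mL/min/kg, a limit of the assay and not a number, and fluoro in place of methyl on an aromatic carbon does not keep its size from one core to the other: the same change on two cores in the Homo sapiens assay, an at least 3.1-fold higher number (0.49 log units; beyond the scatter) from compound 1 to compound 2 and a 1.2-fold lower number (0.07 log units; within the scatter) from compound 3 to compound 4, at least 3.6-fold (0.56 log units) apart, beyond the scatter of two such steps

The new step reads a 1.2-fold lower number from compound 3 to compound 4 (0.07 log units; within the scatter), and the two further steps read a 1.1-fold lower number from compound 2 to compound 4 (0.04 log units; within the scatter) and, for fluoro in place of hydrogen, an at least 2.8-fold higher number from compound 1 to compound 4 (0.45 log units; beyond the scatter); compound 2, compound 3 and compound 4 therefore cannot be ordered, while each gives a higher number than compound 1. The gap between the two steps has only a lower bound, and two instances that also differ in place do not show what the change would do on a further core or whether core or place accounts for the gap: the limit of < 9.9 mL/min/kg in the Homo sapiens assay, at which 1 of the 4 values shown sits.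

In a physicochemical assay for solubility, read by HPLC, in phosphate buffer, with a stated time of 16 h, at pH 6.8 (on this read-out higher numbers stand for higher solubility and lower numbers for lower solubility), compound 3 gives 2700 nM and compound 4 gives 4500 nM. Going by these compounds, in the physicochemical assay the same change reads a 1.7-fold higher number from compound 3 to compound 4 (0.22 log units; within the scatter), and no second core stands beside it there, so whether that step carries to another core remains open. On these data alone, how an amine, a carboxylic acid or a longer chain would read in place of methyl or fluoro, at the place ortho to a large group, also remains open.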